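A few compounds are considered here, and "the series" means these few. Any claim that something is new, unique, unknown or untested is made for them only; others in the source may bear on it.

Compound 1 `CC1(Cc2cccc(C(F)(F)F)c2)CC(S(=O)(=O)c2ccc(F)cc2)=C(c2ccc(/C(N)=N/O)cc2)O1` gives 49800 nM in an ADME assay on cells (Peritoneal macrophage, Mus musculus, strain Balb/c) for cytotoxicity, read by resazurin assay, with a stated time of 72 h; a higher number here means that more compound is tolerated, a lower number that less compound is tolerated. Compound 2 `CC1(Cc2cccc(CO)c2)CC(S(=O)(=O)c2ccc(F)cc2)=C(c2ccc(/C(N)=N/O)cc2)O1` stands only at the limit of this assay, > 100000 nM, a limit and not a number. The step of an at least 2.0-fold higher number from compound 1 to compound 2 (0.30 log units; that floor lies within the scatter) therefore has only a floor, fixed by the limit of > 100000 nM in this assay, at which 1 of the 2 values shown sits. Compound 3 `CC1(Cc2ccc(-c3ccccc3)cc2)CC(S(=O)(=O)c2ccc(F)cc2)=C(c2ccc(/C(N)=N/O)cc2)O1` carries 4-phenylphenyl in place of 3-(hydroxymethyl)phenyl on a saturated chain carbon bound to a saturated ring carbon. Within the data shown here, only that measured step bears on this change: removing trifluoromethyl for hydroxymethyl raised the number, so exchanging the group bearing 1 hydrogen-bond donor for one bearing 0 hydrogen-bond donors is expected to lower it again. Compound 3 is expected to give about 40000 nM in this assay, within 15000 nM to 100000 nM. The expected step is an at least 2.5-fold lower number from compound 2 to compound 3 (0.39 log units; beyond the scatter).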

Compound 3, half-maximal cytotoxic concentration: 33900 nM
Compound 3: the middle estimate sits 1.2-fold (0.07 log units) above what was measured; the range from low to high includes it.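

Exchanging 3-(hydroxymethyl)phenyl for 4-phenylphenyl on the saturated chain carbon gives an at least 2.9-fold lower number from compound 2 to compound 3 (0.46 log units; beyond the scatter) in this assay, and this size is only a floor: the limit of > 100000 nM in this assay, at which 1 of the 3 values shown sits. Set against 3-(trifluoromethyl)phenyl, 4-phenylphenyl gives a 1.5-fold lower number from compound 1 to compound 3 (0.17 log units; within the scatter), so these two groups cannot be told apart here, even with the second aromatic ring. Only the 3-(hydroxymethyl)phenyl group reaches the limit among the three.

From the compounds shown here alone, whether an amine or a carboxylic acid in place of hydroxymethyl would also reach that limit stays open. Going by these compounds, the actual value of compound 2 also stays unknown.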